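Chain Unsaturation Repeated on a Second Core

This account rests on a few compounds, and the source may have more. Where it says the series, first, only, none or still open, it means among the compounds named here.

Measured so far in a functional assay on MDA-MB-231 cells (Homo sapiens) for antiproliferative activity, read by MTT assay; on this read-out lower numbers stand for stronger inhibition and higher numbers for weaker inhibition:
Compound 1 `CCCC/C=C\CCCCCCCCCc1cc(=O)c2c(O)cc(O)c(C)c2o1`: 6790 nM
Compound 2 `CCCCCCCCCCCCCCCc1cc(=O)c2c(O)cc(O)c(C)c2o1`: 6790 nM
Compound 3 `CCCCCCCCCCCCCCCc1cc(=O)c2c(O)c(C)c(O)cc2o1`: 42800 nM

Compound 1 and compound 2 share one core and differ only in the chain: hex-1-en-1-yl in place of hexyl on a saturated chain carbon, nine bonds along the chain from an aromatic carbon. That change produced no change at the digits printed from compound 2 to compound 1 (within the scatter), so the two compounds cannot be ordered against each other. Compound 3 has the same atoms as compound 2, joined differently; the difference between the two cores is not broken down here. Compound 3 gives the highest number of the three, and its gap to compound 1 and to compound 2 lies beyond the scatter.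

Compound 4 `CCCC/C=C\CCCCCCCCCc1cc(=O)c2c(O)c(C)c(O)cc2o1` has not yet been measured. Within the data shown here, it differs from compound 3 by hex-1-en-1-yl in place of hexyl on a saturated chain carbon, nine bonds along the chain from an aromatic carbon, the same change in the same place as the one between compound 2 and compound 1. Because the earlier step gave no change at the digits printed from compound 2 to compound 1 (within the scatter), the step to compound 4 is expected to be small, no change at the digits printed from compound 3 to compound 4 (within the scatter). Compound 4 is therefore estimated at 42800 nM in this assay, with a likely range from 18000 nM to 100000 nM.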

Compound 4, half-maximal inhibitory concentration: 42800 nM
Compound 4: the middle estimate sits on the measured number at the digits printed; low and high end bracket the measured number.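

In this assay, hex-1-en-1-yl in place of hexyl on the second core gave no change at the digits printed from compound 3 to compound 4 (within the scatter). Set beside the same change on the first core, the two steps agree: the same change on two cores in this assay, no change at the digits printed (within the scatter) from compound 2 to compound 1 and no change at the digits printed (within the scatter) from compound 3 to compound 4, 1.0-fold (0.00 log units) apart, within the scatter of two such steps For these two cores, then, the change carries over with no readable effect on antiproliferative activity, but the result rests on only two matched pairs in one assay, so it does not show that the same would hold on any other core, and it gives no cause for the absence of an effect.

The compounds shown leave open whether a double bond elsewhere along the chain, as in oct-3-en-1-yl or non-4-en-1-yl, would behave in the same way, and whether a shorter chain, a longer chain or a chain ending in a carboxylic acid or an amine would move the number on either core. They also leave open whether a core carrying a methoxy group in place of a hydroxyl would respond to the change in the same way.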